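The source may hold more compounds than are shown below. What is called first, only, known or untested is meant among the compounds shown, and "the series" means these compounds.

Notes on the series, from compound 2 to compound 3. In a functional assay on HeLa cells (Homo sapiens) for cytotoxicity, read by cell counting, with a stated time of 72 h (on this read-out higher numbers stand for weaker inhibition and lower numbers for stronger inhibition), compound 1 (`Clc1ncc2sccc2n1`) gives > 250000 nM, which is a limit of the assay. In this assay compound 2 (`Nc1nc(Cl)nc2ccsc12`) gives > 250000 nM, also a limit and not a number, so compound 2 has no readable position in the series. Among the measured compounds shown here, the only measured step, a step that the two limits leave unreadable from compound 1 to compound 2, has no size to carry forward. The evidence so far amounts to the limit of > 250000 nM in this assay, at which 2 of the 2 values shown sit.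

The change to compound 3 (`Clc1nc(-n2cncn2)c2sccc2n1`) is 1H-1,2,4-triazol-1-yl in place of amino on an aromatic carbon, with the chloro group kept. For the measured compounds named here, no measured step covers this exchange, so any size given here is a loose expectation. Only a result on the side of stronger inhibition could be read as a number, and a further limit remains quite possible. The expected change is an at least 8.3-fold lower number from compound 2 to compound 3 (0.92 log units; beyond the scatter), in the direction of stronger inhibition and with low confidence. Compound 3 is estimated at 30000 nM, with an expected range of 3000 nM to 250000 nM.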

Compound 3, half-maximal inhibitory concentration: > 250000 nM
Compound 3 gave a limit, no number; the forecaster's own chance of this, stated with the estimate: 40%; at least 8.3-fold (0.92 log units) between middle value and limit.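

In this assay compound 3 gives > 250000 nM, a limit and not a number. Among the compounds shown here, with compound 1, compound 2 and compound 3 all at limits, no step among them can be read. The compounds shown leave open whether any change on the shared core gives a readable value in this read-out, and of what size.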